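Shifting the methoxy group on a weakly active compound

The source may hold more compounds than are shown below. What is called first, only, known or untested is meant among the compounds shown, and "the series" means these compounds.

In a functional assay on U-251 cells (Homo sapiens) for antiproliferative activity, read by MTT assay, with a stated time of 48 h (on this read-out higher numbers stand for weaker inhibition and lower numbers for stronger inhibition), compound 1 (`COc1cc(-c2cccc3nc(-c4ccccc4)oc23)cc(OC)c1OC`) gives 3500 nM as its half-maximal inhibitory concentration. Compound 2 (`COc1ccc(-c2nc3cccc(-c4cc(OC)c(OC)c(OC)c4)c3o2)cc1`) stands at > 25000 nM and that value is only a limit of the assay. Compound 3 (`COc1cccc(-c2nc3cccc(-c4cc(OC)c(OC)c(OC)c4)c3o2)c1`) carries 3-methoxyphenyl in place of 4-methoxyphenyl on an aromatic carbon of the shared core (3-methoxyphenyl in place of 4-methoxyphenyl on an aromatic carbon). Within the data shown here, the one measured step bearing on this is an at least 7.1-fold higher number from compound 1 to compound 2 (0.85 log units; beyond the scatter) with methoxy in place of hydrogen, and so a moderate move to a lower number is expected. A step of an at least 2.5-fold lower number from compound 2 to compound 3 (0.39 log units; beyond the scatter) is expected in this assay for this change. For compound 3 the estimate is 10000 nM with an expected range from 3000 nM to 30000 nM in that read-out.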

Compound 3, half-maximal inhibitory concentration: > 25000 nM
Compound 3: no number, only a limit; the forecaster's own chance of this, stated with the estimate: 35%; middle value at least 2.5-fold (0.39 log units) away from the limit.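

In this assay, the 3-methoxyphenyl group of compound 3 gives an at least 7.1-fold higher number from compound 1 to compound 3 (0.85 log units; beyond the scatter), so the loss seen with 4-methoxyphenyl also appears when the methoxy group is shifted on the phenyl group. The value of compound 3 is a limit of the assay, so the size of this loss is known only from one side. The step from compound 2 to compound 3 cannot be read, because both values are limits: the limit of > 25000 nM in this assay, at which 2 of the 3 values shown sit.

On these data alone, how far the true values of compound 2 and compound 3 lie from each other stays open. As far as these compounds go, it also stays open whether an amine or a fluorine in place of methoxy on the phenyl group would keep the activity of compound 1.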